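Tert-butoxy for 4-methylpiperidin-1-yl in the series

The source may report more compounds than this note shows. Statements on the series, on what has been measured and on what is new or still open speak of the compounds shown alone.

Values in an ADME assay on Vero cells (Chlorocebus sabaeus) for cytotoxicity, with a stated time of 7 days; a higher number here means that more compound is tolerated, a lower number that less compound is tolerated:
compound 1 `COc1ccc2[nH]c(C(=O)N3CC(=O)N(Cc4ccccc4)[C@@H](COc4ccccc4)C3)cc2c1` gives > 10000 nM
compound 2 `COc1ccc2[nH]c(C(=O)N3CC(=O)N(Cc4ccccc4)[C@@H](COCc4ccccc4)C3)cc2c1` gives > 30000 nM
compound 3 `COc1ccc2[nH]c(C(=O)N3CC(=O)N(Cc4ccccc4)[C@@H](CN4CCC(C)CC4)C3)cc2c1` gives > 30000 nM

All three readings are limits and not numbers. Compound 3 sits at the limit of > 30000 nM in this assay, at which 2 of the 3 values shown sit, in this set. Compound 1 sits at the limit of > 10000 nM in this assay, at which 1 of the 3 values shown sits, in this set.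

Compound 4 `COc1ccc2[nH]c(C(=O)N3CC(=O)N(Cc4ccccc4)[C@@H](COC(C)(C)C)C3)cc2c1` differs from compound 3 as follows: tert-butoxy in place of 4-methylpiperidin-1-yl on a saturated chain carbon bound to a saturated ring carbon and so carries tert-butoxy in place of 4-methylpiperidin-1-yl on a saturated chain carbon bound to a saturated ring carbon.

Closest to this change is a step that the two limits leave unreadable from compound 2 to compound 3 with its swap of benzyloxy for 4-methylpiperidin-1-yl. The other two, a step that the two limits leave unreadable from compound 1 to compound 3 and a step that the two limits leave unreadable from compound 1 to compound 2 in turn, give no size either. For the measured compounds named here, no measured step therefore supports a shift in this assay in either direction, and none beyond the scatter is expected. The expected change is a number no higher from compound 3 to compound 4 (the limit leaves the size open) with no direction favoured. Compound 4 is estimated at 30000 nM with an expected range from 12000 nM to 60000 nM and will probably report a limit again.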

Compound 4, half-maximal cytotoxic concentration: 78200 nM
Estimate against measurement, compound 4: 2.6-fold (0.42 log units) below, outside the stated range (above it).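

In this assay, the steps from compound 1, compound 2 and compound 3 to compound 4 cannot be read: those three readings are limits, and only compound 4 carries a number. From the compounds shown here alone, whether tert-butoxy in place of 4-methylpiperidin-1-yl shifts the tolerated concentration at all remains open.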